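Swapping methoxy for nitro on one aromatic carbon

The compounds below may be only part of what the source reports. "The series", "measured", "known", "first", "only" and "open" are said of these compounds alone.

Three related compounds have been tested in a functional assay on HL-60 cells (Homo sapiens) for inhibition, read by CCK-8 assay, with a stated time of 48 h, tested at 20 uM; on this read-out lower numbers stand for less inhibition of growth and higher numbers for more inhibition of growth at the one concentration tested. Compound 1 (`N#C/C(=C\c1ccccc1OS(=O)(=O)c1ccc([N+](=O)[O-])cc1)C(=O)Nc1nnc(Cc2ccccc2)s1`) gives 20%. Compound 2 (`Cc1ccc(S(=O)(=O)Oc2ccccc2/C=C(\C#N)C(=O)Nc2nnc(Cc3ccc(F)cc3)s2)cc1`) is recorded as "not active" (no number reported), so it offers no number to compare. Compound 3 (`COc1ccc(S(=O)(=O)Oc2ccccc2/C=C(\C#N)C(=O)Nc2nnc(Cc3ccc(F)cc3)s2)cc1`) gives 100%, the highest of the two numbers available, and its gap to compound 1 lies well beyond the usual scatter.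

Compound 4 (`N#C/C(=C\c1ccccc1OS(=O)(=O)c1ccc([N+](=O)[O-])cc1)C(=O)Nc1nnc(Cc2ccc(F)cc2)s1`) has not yet been measured. It is built from compound 3 by putting nitro in place of methoxy on an aromatic carbon, para to a large group, which turns 4-methoxyphenyl into 4-nitrophenyl: nitro in place of methoxy on an aromatic carbon.

The best available guide is compound 1, which also carries the 4-nitrophenyl group and reaches only 20%. With so few compounds, this guide is weak. A large fall, beyond the scatter, is therefore expected, with an estimated step of a number 65 percentage points lower from compound 3 to compound 4 (beyond the scatter). The estimate for compound 4 is 35%, with an expected range from 5% to 80%.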

Compound 4, percent growth inhibition at one concentration: 18%
Compound 4: middle estimate off by 17 percentage points, on the high side; low and high end bracket the measured number.
By their numbers in this assay, from the lowest: compounds 4 and 1 (each within the scatter of the next); then compound 3.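

In this assay, among these compounds, the result gives the first direct one-place comparison at this position: a number 82 percentage points lower from compound 3 to compound 4 (beyond the scatter) with nitro in place of methoxy, so on the same remaining structure 4-methoxyphenyl and 4-nitrophenyl stand far apart. It also gives a second one-place comparison, fluoro in place of hydrogen on an aromatic carbon, which reads a number 2 percentage points lower from compound 1 to compound 4 (within the scatter) and so shows no difference that can be told from scatter when 4-nitrophenyl is present. Nothing measured here explains why the first step is so large.

As far as these compounds go, how an amine or a chloro group would compare at this same position remains open. Also open, from the compounds shown here alone, is whether 4-methoxyphenyl would stand as far above 4-nitrophenyl on the core of compound 1, which has hydrogen in place of the fluoro.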